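The source may hold more compounds than are shown below. What is called first, only, known or untested is meant among the compounds shown, and "the series" means these compounds.

Measured so far:
compound 1 `CN(C)CCN(CCN(C)C)c1cccc(C(=O)N2CCc3ccc(OS(N)(=O)=O)cc3C2)c1` — 0%
compound 2 `NS(=O)(=O)Oc1ccc2c(c1)CN(C(=O)c1cccc(N3CCC(Cc4ccccc4)CC3)c1)CC2` — 1.4%
compound 3 `CN(CCCN1CCCCC1)c1ccc(C(=O)N2CCc3ccc(OS(N)(=O)=O)cc3C2)cc1` — 17.4%

All three numbers come from an assay on HEK293 cells for inhibition of Steryl-sulfatase (Homo sapiens), tested at 0.1 uM; a higher number here means a stronger effect of the compound at the concentration tested, a lower number a weaker effect. Compound 3 stands highest of the three: compound 2 is nearest, lower by more than the scatter, and compound 1 is furthest, also beyond the scatter. Compound 4 `NS(=O)(=O)Oc1ccc2c(c1)CN(C(=O)c1ccc(N3CCCCC3)cc1)CC2` is not yet measured; it differs from compound 3 in one place: piperidin-1-yl in place of methyl(3-(piperidin-1-yl)propyl)amino on an aromatic carbon. Within the data shown here, no pair of measured compounds isolates this change, so the expectation rests on the numbers as they stand: compound 3 is the only one carrying the methyl(3-(piperidin-1-yl)propyl)amino chain, and compound 2, which lacks it, gives 1.4%. A downward step beyond the scatter is therefore expected in this assay. For compound 4 the expected value is 5%, range 0% to 18%, an expected step of a number 12.4 percentage points lower from compound 3 to compound 4 (beyond the scatter).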

Compound 4, a percentage reported as inhibition, at one concentration (the size of the read-out at that concentration, not a potency): 11.5%
Compound 4: middle estimate off by 6.5 percentage points, on the low side, and the stated range covers the measured number.
By their numbers in this assay, from the lowest: compounds 1 and 2 (each within the scatter of the next); then compounds 4 and 3 (each within the scatter of the next).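

In this assay, piperidin-1-yl in place of methyl(3-(piperidin-1-yl)propyl)amino on an aromatic carbon, para to a large group, gives a number 5.9 percentage points lower from compound 3 to compound 4 (within the scatter). Among these compounds, this is the first pair isolating a change at this position, and it shows that the chain can be cut back to the ring alone without a change beyond the scatter at this single concentration. No measured evidence bears on this result.

Open, as far as these compounds go, is whether a dimethylamino group, a morpholin-4-yl ring or a longer chain ending in a carboxylic acid on this aromatic carbon would shift the read-out beyond the scatter. Potency also remains open, since one concentration gives only the size of the read-out.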